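Aryl swap on the shared core: cytotoxicity notes

A few compounds are considered here, and "the series" means these few. Any claim that something is new, unique, unknown or untested is made for them only; others in the source may bear on it.

Compound 1 `COc1nc2ccccc2cc1/C=C/c1noc(-c2ccccc2)n1` and compound 2 `COc1nc2ccccc2cc1/C=C/c1noc(-c2ccccc2Br)n1` share one core. In an ADME assay on HepG2 cells (Homo sapiens) for cytotoxicity, read by sulforhodamine B assay, with a stated time of 48 h (a lower number here means that less compound is tolerated, a higher number that more compound is tolerated), compound 1 gives > 240000 nM, a limit of the assay. In this assay compound 2 gives > 195000 nM, again a limit. The step that the two limits leave unreadable from compound 1 to compound 2 is therefore not readable. Compound 3 `COc1cccc(-c2nc(/C=C/c3cc4ccccc4nc3OC)no2)c1` carries 3-methoxyphenyl in place of 2-bromophenyl on an aromatic carbon. Within the data shown here, only this unreadable step bears on the change, and both values shown sit at limits, the limit of > 195000 nM in this assay, at which 1 of the 2 values shown sits, and (the limit of > 240000 nM in this assay, at which 1 of the 2 values shown sits). No step beyond the scatter is expected in this assay. Compound 3 is estimated at 220000 nM, within 80000 nM to 500000 nM, most likely reported as a limit again. The expected step is a step that the limit leaves unreadable from compound 2 to compound 3.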

Compound 3, half-maximal cytotoxic concentration: > 220000 nM
Compound 3 ended at the assay's limit; the forecaster's own chance of this, stated with the estimate: 80%; the middle value sits exactly at the limit.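

Among these compounds, compound 3, like compound 1 and compound 2, sits at a limit, and no step from compound 1 or compound 2 to compound 3 can be read. The concentration at which any of these compounds stops being tolerated stays open in this assay.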